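Amino for Methylsulfanyl on the Hydroxamate Chain

The source may report more compounds than this note shows. Statements on the series, on what has been measured and on what is new or still open speak of the compounds shown alone.

Among the measured compounds shown here, compound 2 `CSC[C@H](NC(=O)c1ccc(C#Cc2ccccc2)cc1)C(=O)NO` stands at 3 in a physicochemical assay for lipophilicity (a lower number here means a more polar compound, a higher number a more lipophilic compound), the only number given in the set. Compound 1 `O=C(NC1(C(=O)NO)CCCCC1)c1ccc(C#Cc2ccccc2)cc1` returns a limit of this assay rather than a number, > 3. Among the two values shown, compound 1 marks (the limit of > 3 in this assay, at which 1 of the 2 values shown sits). Compound 3 `NC[C@H](NC(=O)c1ccc(C#Cc2ccccc2)cc1)C(=O)NO` has not yet been measured; it differs from compound 2 by amino in place of methylsulfanyl on a saturated chain carbon, two bonds along the chain from an amide-type nitrogen and a carbonyl carbon. For the measured compounds named here, no measured step of this kind exists here, so the size is open. The step from compound 2 to compound 3 is expected to be a number 1.70 log units lower from compound 2 to compound 3 (beyond the scatter), toward the polar side and beyond the scatter. Compound 3 is therefore estimated at 1.3, between 0.5 and 2.2.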

Compound 3, distribution coefficient: 2
The estimate for compound 3 lay 0.70 log units below the measured number; low and high end bracket the measured number.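

With amino in place of methylsulfanyl on a saturated chain carbon, two bonds along the chain from an amide-type nitrogen and a carbonyl carbon, this assay gives a number 1.00 log units lower from compound 2 to compound 3 (beyond the scatter). Among the compounds shown here, this is the first measured step at this position, and the earlier compounds, with no step between them, could not show that the read-out responds to a change here.

On these data alone, how a carboxylic acid, a hydroxyl or a dimethylamino group in the same place would read remains open. Nothing shown accounts for the size of this step.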